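Anilino Variation on a Shared Core in Leukemia Cells

A few compounds are considered here, and "the series" means these few. Any claim that something is new, unique, unknown or untested is made for them only; others in the source may bear on it.

Compound 3 `Cc1n[nH]c2ccc(-c3nc4cnc(N5CCN(C)CC5)cn4c3Nc3ccc(Br)cc3)cc12` stands second highest of the three numbers recorded in a functional assay on MV4-11 cells (Homo sapiens) for inhibition, with a stated time of 120 h, tested at 10 uM; a lower number here means less inhibition, a higher number more inhibition at the concentration tested (going by the name of the read-out). Compound 2 `Cc1n[nH]c2ccc(-c3nc4cnc(N5CCN(C)CC5)cn4c3Nc3ccc(Cl)cc3)cc12` gives 83.7%, and a number 0.7 percentage points lower from compound 2 to compound 3 (within the scatter) leaves compound 3 at 83%, the two lying within the scatter. Compound 1 `Cc1n[nH]c2ccc(-c3nc4cnc(N5CCN(C)CC5)cn4c3Nc3ccccc3F)cc12` gives 0%, so a number 83.7 percentage points higher from compound 1 to compound 2 (beyond the scatter) and a number 83 percentage points higher from compound 1 to compound 3 (beyond the scatter) are both large. Compound 4 `Cc1ccc(C)c(Nc2c(-c3ccc4[nH]nc(C)c4c3)nc3cnc(N4CCN(C)CC4)cn23)c1` differs from compound 3 by 2,5-dimethylphenyl in place of 4-bromophenyl on a nitrogen on an aromatic ring. Within the data shown here, no measured step covers this exchange; the only steps altering the aryl group are the two large rises from compound 1, while halogen exchange between compound 2 and compound 3 mattered little. Because compound 1 with its 2-fluorophenyl gives 0%, compound 4 is expected to drop, with a step of a number 48 percentage points lower from compound 3 to compound 4 (beyond the scatter) in this assay. The estimate for compound 4 is 35%, ranging from 0% to 80%.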

Compound 4, a percentage reported as inhibition, at one concentration (the size of the read-out at that concentration, not a potency): 0%
For compound 4 the middle estimate is 35 percentage points above the measured one, and the stated range covers the measured number.
By their numbers in this assay, from the lowest: compounds 1 and 4 (each within the scatter of the next); then compounds 3 and 2 (each within the scatter of the next).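

In this assay, 2,5-dimethylphenyl on the nitrogen removes the whole read-out seen with the halogenated aryl groups, with a number 83 percentage points lower from compound 3 to compound 4 (beyond the scatter) and a number 83.7 percentage points lower from compound 2 to compound 4 (beyond the scatter). Against 2-fluorophenyl there is no change at the digits printed from compound 1 to compound 4 (within the scatter), so the 2-fluorophenyl and 2,5-dimethylphenyl compounds stand together, apart from the 4-chlorophenyl and 4-bromophenyl compounds, and a group without halogen now shares the low end. No evidence bearing on the cause of this result is available.

Open, going by these compounds, is whether 4-methylphenyl or unsubstituted phenyl on the same nitrogen would match compound 2 and compound 3, which would show which methyl of the 2,5-dimethylphenyl goes with the drop.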